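Sulfonylamino substitution in the series: outlook for compound 4

This account rests on a few compounds, and the source may have more. Where it says the series, first, only, none or still open, it means among the compounds named here.

In a functional assay on NCI-H460 cells (Homo sapiens) for cytotoxicity, read by MTT assay, with a stated time of 96 h (on this read-out lower numbers stand for stronger inhibition and higher numbers for weaker inhibition), compound 3 `COc1ccc(-c2cc(OC3CCOCC3)c3nc(N)nc(C)c3c2)cn1` gives 980 nM. That value lies within the scatter of the other two: compound 1 `COc1ncc(-c2cc(OC3CCOCC3)c3nc(N)nc(C)c3c2)cc1NS(C)(=O)=O` gives 860 nM and compound 2 `COc1ncc(-c2cc(OC3CCOCC3)c3nc(N)nc(C)c3c2)cc1F` gives 1100 nM. Compound 4 `COc1ncc(-c2cc(OC3CCOCC3)c3nc(N)nc(C)c3c2)cc1NS(=O)(=O)c1ccc(F)cc1Cl` differs from compound 3 by ((2-chloro-4-fluorophenyl)sulfonyl)amino in place of hydrogen on an aromatic carbon, with ((2-chloro-4-fluorophenyl)sulfonyl)amino in place of hydrogen on an aromatic carbon, ortho to a methoxy group. All three measured steps concern this same carbon. The closest is a 1.1-fold higher number from compound 1 to compound 3 (0.06 log units; within the scatter), which exchanges methanesulfonamido and hydrogen. The others are a 1.3-fold higher number from compound 1 to compound 2 (0.11 log units; within the scatter) and a 1.1-fold lower number from compound 2 to compound 3 (0.05 log units; within the scatter). None of them leaves the scatter, so no step beyond the scatter is expected here. Going by the values given here, the entering group also holds an aromatic ring, and no measured compound tests that ring, so the range stays wide and leans slightly towards lower numbers. The expected change is a 1.6-fold lower number from compound 3 to compound 4 (0.21 log units; within the scatter). The estimate for compound 4 is 600 nM, with an expected range of 120 nM to 1500 nM.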

Compound 4, half-maximal inhibitory concentration: 17 nM
Compound 4: the middle estimate sits 35-fold (1.55 log units) above what was measured; the whole stated range lies above it.
By their numbers in this assay, from the lowest: compound 4; then compounds 1, 3 and 2 (each within the scatter of the next).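

In this assay, the aromatic carbon ortho to a methoxy group proves able to carry a large change: hydrogen, fluoro and methanesulfonamido stay within the scatter of one another, whereas ((2-chloro-4-fluorophenyl)sulfonyl)amino gives a 58-fold lower number from compound 3 to compound 4 (1.76 log units; beyond the scatter) and a 65-fold lower number from compound 2 to compound 4 (1.81 log units; beyond the scatter) in the fluoro comparison. The sulfonylamino link alone does not give this step, since compound 1 already carries it, and 2-chloro-4-fluorophenyl in place of methyl on the sulfonyl sulfur gives a 51-fold lower number from compound 1 to compound 4 (1.70 log units; beyond the scatter) as the change. Nothing available gives a reason for the size of these steps.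

A plain phenyl on the sulfonyl sulfur would separate the contribution of the aromatic ring from that of its chlorine and fluorine. On these data alone, whether a longer alkyl chain or a pyridine ring there could match compound 4 remains open.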